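Swapping the halogenated ring in a bis-benzylidene cyclohexanone

This account rests on a few compounds, and the source may have more. Where it says the series, first, only, none or still open, it means among the compounds named here.

Three compounds share one core, a cyclohexanone carrying two benzylidene arms. Compound 1, `COc1cccc(/C=C2\CCC/C(=C\c3ccc(Cl)c(Cl)c3)C2=O)c1OC`, compound 2, `COc1cc(/C=C2\CCC/C(=C\c3cccc(OC)c3OC)C2=O)cc(OC)c1`, and compound 3, `COc1ccc(/C=C2\CCC/C(=C\c3ccccc3Br)C2=O)cc1OC`, were each tested in a functional assay on SW-620 cells (Homo sapiens) for cytotoxicity, read by MTT assay, with a stated time of 72 h; a lower number here means a stronger inhibitor, a higher number a weaker inhibitor. Compound 1 gives 10000 nM, compound 2 gives 3800 nM, and compound 3 gives 5300 nM. Among these three numbers compound 3 stands second highest, yet its gap to compound 2 and its gap to compound 1 both lie within the scatter of this assay, so no ordering among them can be claimed.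

Compound 4, `COc1ccc(/C=C2\CCC/C(=C\c3cc(Cl)cc(Cl)c3)C2=O)cc1OC`, is not yet measured. It differs from compound 3 in one place: 3,5-dichlorophenyl in place of 2-bromophenyl on a double-bonded chain carbon bound to a double-bonded ring carbon. Among the compounds with values here, no measured pair isolates this exact exchange, so the expectation rests on the spread of the three numbers. The step from compound 3 to compound 4 is expected to be small, most likely a weakening, as a 1.3-fold higher number from compound 3 to compound 4 (0.12 log units; within the scatter). For compound 4 the estimated value in this assay is 7000 nM, within a range from 2500 nM to 20000 nM.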

Compound 4, half-maximal inhibitory concentration: 2500 nM
Beside the measured number, compound 4's estimate is 2.8-fold (0.45 log units) above it, and the stated range covers the measured number.
By their numbers in this assay, from the lowest: compounds 4, 2, 3 and 1 (each within the scatter of the next, the first and the last beyond it).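

In this assay, within the data shown here, putting 3,5-dichlorophenyl in place of 2-bromophenyl on a double-bonded chain carbon bound to a double-bonded ring carbon gives a 2.1-fold lower number from compound 3 to compound 4 (0.33 log units; beyond the scatter) and so provides the first step in this set that lies beyond the scatter. The change is modest, but it shows that this arm of the molecule can shift the number while the rest of the structure stays the same. No measurement here accounts for the shift, so its cause remains unknown.

This single exchange alters the halogen, the number of halogens and their places on the ring together, so it cannot show which of these matters. Also open, going by these compounds, is how the number would respond in this place to a ring carrying an amine or a carboxylic acid.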